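The source may report more compounds than this note shows. Statements on the series, on what has been measured and on what is new or still open speak of the compounds shown alone.

Two compounds have been measured in a functional assay on MDA-MB-231 cells (Homo sapiens) for cytotoxicity, read by sulforhodamine B assay; a higher number here means a weaker inhibitor, a lower number a stronger inhibitor:

compound 1 `COc1ccc(-c2cc3cc(C)ccc3c(N)n2)c(C)c1`: 150 nM
compound 2 `COc1cccc(-c2cc3cc(OC)c(OC)cc3c(N)n2)c1`: 140 nM

Among these two numbers, compound 2 stands at 140 nM, with compound 1 at 150 nM only a short distance away, a gap that lies inside the scatter of repeated measurements. The two values therefore show no separation, and neither compound can be set apart from the other on what has been measured.

Compound 3 `COc1cc(OC)cc(-c2cc3cc(OC)c(OC)cc3c(N)n2)c1` has not yet been measured in this assay. It differs from compound 2 in one place: methoxy in place of hydrogen on an aromatic carbon. Within the data shown here, no pair of measured compounds shows this change, so there is no measured step to lean on. With nothing in the data pointing either way, the expected step from compound 2 to compound 3 is a 1.1-fold higher number from compound 2 to compound 3 (0.03 log units; within the scatter), which is taken as none beyond the scatter. Compound 3 is accordingly expected to give about 150 nM, estimated to fall between 60 nM and 400 nM.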

Compound 3, half-maximal inhibitory concentration: 400 nM
For compound 3 the middle estimate is 2.7-fold (0.43 log units) below the measured one, and the stated range covers the measured number.
By their numbers in this assay, from the lowest: compounds 2 and 1 (each within the scatter of the next); then compound 3.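

In this assay this position proves not to be neutral: methoxy in place of hydrogen, on an aromatic carbon meta to a large group and meta to a methoxy group, gives a 2.9-fold higher number from compound 2 to compound 3 (0.46 log units; beyond the scatter) and so marks a modest loss. Among these compounds, the two earlier compounds could not be told apart and offered no single change to follow, which makes this the first reading of what one substitution does on the shared core. Nothing available explains why the number rises with this change.

On these data alone, it remains open whether the loss belongs to methoxy itself or would follow any group placed on this carbon, since only hydrogen and methoxy are compared here. A hydroxyl, a fluorine atom, an amine or a longer chain such as ethoxy at the same place would show how the number tracks the group, and one pair cannot say whether the same change would act alike on the core of compound 1.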